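The compounds below may be only part of what the source reports. "The series", "measured", "known", "first", "only" and "open" are said of these compounds alone.

Working notes on the series, read in a functional assay on HeLa cells (Homo sapiens) for antiproliferative activity, read by MTT assay, with a stated time of 72 h; a lower number here means a stronger inhibitor, a higher number a weaker inhibitor. Compound 1 `COc1cc(-c2nccn2C)cc(OC)c1OC` gives > 100000 nM, which is a limit of the assay and not a number. Compound 2 `CCCn1ccnc1-c1cc(OC)c(OC)c(OC)c1` gives > 100000 nM, again a limit and not a number. Compound 2 therefore has no numerical position in this assay and stands with compound 1 at the limit of > 100000 nM in this assay, at which 2 of the 2 values shown sit.

The next change leads to compound 3 `COc1cc(-c2nccn2C(C)C)cc(OC)c1OC`: isopropyl in place of propyl on an aromatic nitrogen. This places isopropyl in place of propyl on an aromatic nitrogen, next to the ring atom that bears a large group.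

Among the measured compounds shown here, the only measured step bearing on this change is a step that the two limits leave unreadable from compound 1 to compound 2. It concerns the same aromatic nitrogen, but it gives no size to carry forward. Compound 2 offers only the limit of > 100000 nM as a starting point, so no step beyond the scatter is expected and no direction can be assigned. The expected outcome is a number no higher from compound 2 to compound 3 (the limit leaves the size open). For compound 3, the estimated value is 100000 nM, with an expected range of 30000 nM to 300000 nM.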

Compound 3, half-maximal inhibitory concentration: > 100000 nM
Compound 3 ended at the assay's limit; the forecaster's own chance of this, stated with the estimate: 85%; the middle value lies on the limit itself.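

In this assay, among the compounds shown here, compound 3 gives > 100000 nM, a limit of the assay and not a number, so no step among compound 1, compound 2 and compound 3 can be read. All three compounds stand together: the limit of > 100000 nM in this assay, at which 3 of the 3 values shown sit.

The compounds shown leave open whether methyl, propyl and isopropyl on this aromatic nitrogen differ at all in this read-out, and by how much.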